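The compounds below may be only part of what the source reports. "The series", "measured", "known", "first", "only" and "open" are said of these compounds alone.

Working notes on the series. In an assay on isolated protein for activation of cGMP-dependent protein kinase 1 (Homo sapiens), read by ADP-Glo, with stated times of 30 min and 2 h (on this read-out lower numbers stand for an effect already at smaller amounts and higher numbers for an effect only at larger amounts of compound), compound 1 `O=C(O)C12CC(CN3CCC[C@H](O[C@H](CO)c4cc(Cl)cc(Cl)c4)[C@@H]3c3ccccc3)(C1)C2` gives > 200000 nM, which is a limit of the assay and not a number. Compound 2 `Cc1cc(C(=O)O)ccc1CN1CCC[C@H](O[C@H](CO)c2ccnc(Cl)c2)[C@@H]1c1ccccc1` in this assay gives > 200000 nM, again a limit. On the numbers shown, compound 1 stands at the limit of > 200000 nM in this assay, at which 2 of the 2 values shown sit, with no value beneath it. Compound 3 `Nc1cc(C(=O)O)ccc1CN1CCC[C@H](O[C@H](CO)c2cc(Cl)cc(Cl)c2)[C@@H]1c1ccccc1` differs from compound 1 as follows: a group of 10 heavy atoms (7 carbon, 1 nitrogen, 2 oxygen; one six-membered aromatic ring of carbon only) in place of a group of 8 heavy atoms (6 carbon, 2 oxygen; 2 four-membered non-aromatic rings of carbon only), on a saturated chain carbon bound to an amine nitrogen in a ring. No step between measured compounds is shown. Compound 2 also carries a carboxylic acid on an aromatic ring and sits at the limit, so no movement beyond the scatter is expected. Compound 3 is expected to give 300000 nM, between 60000 nM and 1500000 nM, most likely reported as a limit again. The expected step from this change is a step that the limit leaves unreadable from compound 1 to compound 3.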

Compound 3, half-maximal effective concentration: 168000 nM
Compound 3: the middle estimate sits 1.8-fold (0.25 log units) above what was measured; the range from low to high includes it.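

In this assay, going by these compounds alone, 2-amino-4-carboxyphenyl at this saturated chain carbon gives the first reading that is a number and not a limit, with an at least 1.1-fold lower number from compound 1 to compound 3 (0.07 log units; that floor lies within the scatter). That step is only a floor, so its true size stays unread and no gain beyond the scatter can be claimed. The other two values remain limits: the limit of > 200000 nM in this assay, at which 2 of the 3 values shown sit.

Open, going by these compounds, is whether this reading goes with the amine or with the aromatic ring itself. Also open, on these data alone, is how an amide in place of the carboxylic acid would read.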